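The source may hold more compounds than are shown below. What is called first, only, known or untested is meant among the compounds shown, and "the series" means these compounds.

Compound 1 `CCc1ccc(NC(=O)N[C@H](C)c2ccccc2)cc1`: 95%
Compound 2 `CCc1ccc(NC(=O)N[C@@H](C)c2ccccc2)cc1`: 99%
Compound 3 `CC(C)c1cccc(NC(=O)N[C@H](C)c2ccccc2)c1`: 74%

Of the compounds shown here, three have been measured in an ADME assay on the whole organism with Oryza sativa as the target, tested at 0.1 uM; a higher number here means a weaker effect of the compound at the concentration tested, a lower number a stronger effect. Compound 1 gives 95%, the second highest of the three numbers. Compound 2 gives 99%, and compound 3 gives 74%, the lowest of the three. Going by the values given here, the only step between compounds that differ in one place is a number 4 percentage points higher from compound 1 to compound 2 (within the scatter); that step rests on the fact that (the fact that compounds 1 and 2 differ only in the configuration as drawn), so a change in drawn configuration alone leaves the read-out where it was. Compound 3 differs from compound 1 in two places at once, so its lower number cannot be tied to a single change.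

Compound 4 `CCCCCc1ccc(NC(=O)N[C@H](C)c2ccccc2)cc1` has not yet been measured. It differs from compound 1 by propyl in place of hydrogen on a saturated chain carbon, two bonds along the chain from an aromatic carbon. Among the compounds with values here, no measured step describes a lengthening of this chain: the step from compound 1 to compound 2 concerns only configuration, and the gap between compound 1 and compound 3 mixes two changes. With nothing pointing one way or the other, and compound 1 already standing near the top of the scale, the expected step is a number 3 percentage points lower from compound 1 to compound 4 (within the scatter), a change not beyond the scatter. The value expected for compound 4 is therefore 92%, with a range from 75% to 100%.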

Compound 4, a percentage reported as activity, at one concentration (the size of the read-out at that concentration, not a potency): 100%
The estimate for compound 4 lay 8 percentage points below the measured number; the range from low to high includes it.
By their numbers in this assay, from the lowest: compound 3; then compounds 1, 2 and 4 (each within the scatter of the next).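

At this place, on a saturated chain carbon two bonds along the chain from an aromatic carbon, putting propyl in place of hydrogen turns the ethyl group into a pentyl group, and in this assay the outcome is a number 5 percentage points higher from compound 1 to compound 4 (within the scatter) for this change. Going by these compounds alone, this is the first measured step that alters a group and not just the drawn configuration, and it shows that the chain can grow from ethyl to pentyl at this place without moving the read-out beyond the usual scatter, so lengthening the chain this far brings no clear gain in effect at the concentration tested. No fact at hand bears on why the longer chain leaves the read-out where it was.

On these data alone, whether a still longer chain such as octyl, or a chain ending in an amine or a carboxylic acid, would behave the same way at this place remains open. The number for compound 3 also cannot be tied to a single change, so the compounds shown contain no single-place step that clearly moves this read-out.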